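The source may hold more compounds than are shown below. What is called first, only, known or untested is meant among the compounds shown, and "the series" means these compounds.

Measured compounds in a functional assay on T47D cells (Homo sapiens) for inhibition, read by sulforhodamine B assay, with a stated time of 48 h; a lower number here means a stronger inhibitor of growth, a higher number a weaker inhibitor of growth:

Compound 1, `Nc1cc(N)c2nc(-c3ccccc3)c(Oc3ccc(Cl)c(Cl)c3)nc2c1`, gives 79400 nM in this assay.
Compound 2, `Nc1cc(N)c2nc(-c3ccccc3)c(NCc3ccc(Cl)c(Cl)c3)nc2c1`, gives 55000 nM in this assay.
Compound 3, `CCOC(=O)[C@H](CCC(=O)O)NC(=O)c1ccc(Sc2nc3cc(N)cc(N)c3nc2-c2ccccc2)cc1`, reaches only a limit of the assay, < 100000 nM, in this assay; this is a boundary of what the assay reports, not a number.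

All three share the same core, a fused ring system carrying two amino groups and a phenyl ring, and differ in what hangs from the remaining position. Compound 2 carries a 3,4-dichlorobenzyl group joined through a nitrogen. Its number and that of compound 1 sit within the usual scatter of each other, so no order between them can be read; for compound 3 only the limit is known (the limit of < 100000 nM in this assay, at which 1 of the 3 values shown sits).

Compound 4, `COc1ccc(CNc2nc3cc(N)cc(N)c3nc2-c2ccccc2)cc1`, is not yet measured. It differs from compound 2 in one place: 4-methoxyphenyl in place of 3,4-dichlorophenyl on a saturated chain carbon bound to a nitrogen on an aromatic ring. Going by the values given here, no measured pair shows this kind of swap, so there is no step to lean on. Without such a reference, the expectation is that the step from compound 2 to compound 4 in this assay stays within the scatter or drifts to a modestly higher number, a 1.3-fold higher number from compound 2 to compound 4 (0.10 log units; within the scatter).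

On that basis compound 4 is estimated at 70000 nM, with a plausible range from 20000 nM to 200000 nM.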

Compound 4, concentration for total growth inhibition: 11000 nM
Compound 4: the middle estimate sits 6.4-fold (0.80 log units) above what was measured; the whole stated range lies above it.
By their numbers in this assay, from the lowest: compound 4; then compounds 2 and 1 (each within the scatter of the next).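

In this assay the group carried on the nitrogen turns out to matter: going from 3,4-dichlorobenzyl to 4-methoxybenzyl gives a 5.0-fold lower number from compound 2 to compound 4 (0.70 log units; beyond the scatter) and so moves the number by more than repeated measurements would. Before this result, no two measured compounds differed in one place, so nothing had shown that a swap on the aromatic ring of this benzyl group could change growth inhibition in these cells. Nothing measured here bears on why the number falls.

From the compounds shown here alone, a single pair also cannot separate the two parts of the swap, the loss of both chlorine atoms and the gain of the methoxy group, so it remains open which of them accounts for the step, or whether both are needed. A plain benzyl group with no substituent on its ring, a benzyl group carrying a single chlorine or a hydroxyl group, and a longer chain between the nitrogen and the ring would each test a different part of this question, and none of them can be judged from the compounds shown.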